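The source may report more compounds than this note shows. Statements on the series, on what has been measured and on what is new or still open speak of the compounds shown alone.

The series shares one core, varied only at an amine nitrogen in a ring. Compound 1 `CC(C)(C)OC(=O)N1CCc2c(sc(NC(=O)Nc3ccc(Cl)cc3)c2C(N)=O)C1` carries tert-butoxycarbonyl there, compound 2 `CC(C)(C)OC(=O)CCN1CCc2c(sc(NC(=O)Nc3ccc(Cl)cc3)c2C(N)=O)C1` carries 2-(tert-butoxycarbonyl)ethyl, and compound 3 `CC(C)N1CCc2c(sc(NC(=O)Nc3ccc(Cl)cc3)c2C(N)=O)C1` carries isopropyl. In a functional assay (strain AB) with Danio rerio as the target, read by microscopy, with a stated time of 1 h (a lower number here means that less compound is needed, a higher number that more compound is needed for the effect), compound 1 reaches only the limit of the assay, > 25000 nM. In this assay compound 2 gives 1100 nM, and compound 3 gives 1490 nM. The steps of an at least 22-fold lower number from compound 1 to compound 2 (1.35 log units; beyond the scatter) and an at least 16-fold lower number from compound 1 to compound 3 (1.22 log units; beyond the scatter) both start from that limit (the limit of > 25000 nM in this assay, at which 1 of the 3 values shown sits), so their true size is open beyond the floor stated. Between the two numbered compounds the step is a 1.4-fold higher number from compound 2 to compound 3 (0.13 log units; within the scatter). Compound 2 thus holds the lower of the two numbers, with compound 3 within the scatter of it.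

Compound 4 `CC(C)(C)OC(=O)CCCCCN1CCc2c(sc(NC(=O)Nc3ccc(Cl)cc3)c2C(N)=O)C1` is the next member. Relative to compound 2 the change is 3-(tert-butoxycarbonyl)propyl in place of tert-butoxycarbonyl on a saturated chain carbon, two bonds along the chain from an amine nitrogen in a ring. Among the measured compounds shown here, no measured step in the set extends this chain; the only step among numbered compounds, a 1.4-fold higher number from compound 2 to compound 3 (0.13 log units; within the scatter), shows that exchanging 2-(tert-butoxycarbonyl)ethyl for isopropyl left the number where it was, while both compounds sit far from the limit of compound 1. The expectation for this assay is therefore no step beyond the scatter in either direction; the estimated step is a 1.1-fold higher number from compound 2 to compound 4 (0.04 log units; within the scatter). Compound 4 is expected at 1200 nM, with a range from 500 nM to 3500 nM.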

Compound 4, half-maximal effective concentration: 620 nM
For compound 4 the middle estimate is 1.9-fold (0.29 log units) above the measured one; measured number inside the range.
By their numbers in this assay, from the lowest: compounds 4, 2 and 3 (each within the scatter of the next, the first and the last beyond it). At a limit, above all of these: compound 1.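

In this assay, the longer chain on the saturated chain carbon, two bonds along the chain from an amine nitrogen in a ring, is tolerated: a 1.8-fold lower number from compound 2 to compound 4 (0.25 log units; within the scatter). This adds a new kind of evidence, since the earlier comparison exchanged 2-(tert-butoxycarbonyl)ethyl for isopropyl, whereas here the terminal tert-butoxycarbonyl is kept and 3-(tert-butoxycarbonyl)propyl brings 10 heavy atoms where tert-butoxycarbonyl had 7, with the same counts of hydrogen-bond donors and acceptors. The two ends of the measured order, compound 4 at 620 nM and compound 3 at 1490 nM, are printed as lying beyond the scatter of each other, although each is within the scatter of compound 2, so the series gives only a weak separation among these three substituents.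

The compounds shown leave open whether a still longer chain on the same nitrogen would keep a number in this range, and whether the terminal tert-butoxycarbonyl is needed at all, as a carboxylic acid, an amine or a plain alkyl chain of the same length at that end would show. Compound 1 remains a limit, and its steps cannot be read for size: the limit of > 25000 nM in this assay, at which 1 of the 4 values shown sits.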